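Trifluoromethyl to Nitro on the Benzyl Ether Arm

The source may report more compounds than this note shows. Statements on the series, on what has been measured and on what is new or still open speak of the compounds shown alone.

Measured compounds:
compound 1 `FC(F)(F)c1ccc(COc2cccc(Nc3ncnc4cc5c(cc34)OCCOCCOCCOCCO5)c2)cc1`: 8560 nM
compound 2 `FC(F)(F)c1ccc(COc2ccccc2Nc2ncnc3cc4c(cc23)OCCOCCO4)cc1`: > 100000 nM (a limit of the assay)
compound 3 `FC(F)(F)c1ccc(COc2cccc(Nc3ncnc4cc5c(cc34)OCCOCCOCCO5)c2)cc1`: 20000 nM

All three were tested in a functional assay on SH-SY5Y cells (Homo sapiens) for antiproliferative activity, read by MTT assay, with a stated time of 72 h; a lower number here means a stronger inhibitor, a higher number a weaker inhibitor. Among the two numbers on hand, compound 1 gives the lowest; compound 3 sits higher, and that gap lies beyond the usual scatter of repeated measurements. For compound 2 the result is the limit of > 100000 nM in this assay, at which 1 of the 3 values shown sits, a limit rather than a number.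

Compound 4 `O=[N+]([O-])c1ccc(COc2cccc(Nc3ncnc4cc5c(cc34)OCCOCCOCCOCCO5)c2)cc1` has not yet been measured. It differs from compound 1 in one place: nitro in place of trifluoromethyl on an aromatic carbon. In other words, the (4-(trifluoromethyl)benzyl)oxy group becomes a (4-nitrobenzyl)oxy group, the change sitting para to a large group on the phenyl ring, while the shared core of compound 1 stays untouched.

Going by the values given here, no measured pair isolates this exact swap, so no step size is known from the data. The expectation for the step from compound 1 to compound 4 in this assay is a 1.2-fold higher number from compound 1 to compound 4 (0.07 log units; within the scatter), a change expected to stay within the scatter. Compound 4 is therefore estimated at 10000 nM, with a range expected from 3000 nM to 40000 nM.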

Compound 4, half-maximal inhibitory concentration: 8420 nM
Beside the measured number, compound 4's estimate is 1.2-fold (0.07 log units) above it, and the stated range covers the measured number.
By their numbers in this assay, from the lowest: compounds 4 and 1 (each within the scatter of the next); then compound 3. At a limit, above all of these: compound 2.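

In this assay, the swap reads as a 1.0-fold lower number from compound 1 to compound 4 (0.01 log units; within the scatter), so the two compounds cannot be told apart in this assay. Going by these compounds alone, the earlier compounds offered no pair differing only on this aromatic carbon, para to a large group, so this is the first direct reading of the position: with the shared core held the same, nitro can stand in place of trifluoromethyl with no measurable difference, even though nitro brings hydrogen-bond acceptors that trifluoromethyl lacks. Nothing in the data shown explains why the two groups read alike here.

What the compounds shown leave open is whether this position tolerates groups in general, or only these two: an amine, a carboxylic acid or a simple methoxy group in the same place could read quite differently, and a single pair cannot show which. On these data alone, it also remains open whether the same swap would read alike on the core of compound 3 or in any other assay, since this one step comes from a single core and a single cell line.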